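The compounds below may be only part of what the source reports. "The series", "measured", "known", "first", "only" and "open" are said of these compounds alone.

Measured compounds:
- Compound 1, `NC(=O)c1c(NC(=O)c2ccccc2)sc2c1CCN(C(=S)Nc1ccccc1Cl)C2`: in a functional assay on HeLa cells (Homo sapiens) for antiproliferative activity, with a stated time of 24 h (on this read-out lower numbers stand for stronger inhibition and higher numbers for weaker inhibition), compound 1 gives > 50000 nM, which is a limit of the assay and not a number.
- Compound 2, `NC(=O)c1c(NC(=O)c2ccccc2F)sc2c1CCN(C(=S)Nc1ccccc1Cl)C2`: in this assay compound 2 gives 19400 nM.
- Compound 3, `NC(=O)c1c(NC(=O)c2ccc(C(F)(F)F)cc2)sc2c1CCN(C(=S)Nc1ccccc1Cl)C2`: in this assay compound 3 gives 44000 nM.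

Compound 3 carries the higher of the two numbers actually read; its nearest neighbour is compound 2, with a 2.3-fold higher number from compound 2 to compound 3 (0.36 log units; beyond the scatter). Compound 1 sits at the limit of > 50000 nM in this assay, at which 1 of the 3 values shown sits. Accordingly an at least 1.1-fold lower number from compound 1 to compound 3 (0.05 log units; that floor lies within the scatter) is only a floor and lies within the scatter. Within the data shown here, the one change that clears the scatter is an at least 2.5-fold lower number from compound 1 to compound 2 (0.41 log units; beyond the scatter).

Compound 4, `NC(=O)c1c(NC(=O)c2ccncn2)sc2c1CCN(C(=S)Nc1ccccc1Cl)C2`, is the next member: pyrimidin-4-yl in place of 4-(trifluoromethyl)phenyl on a carbonyl carbon. Among the measured compounds shown here, none of the measured steps swaps the ring on this carbonyl for one containing hetero atoms; the closest comparisons are the exchange of one substituted phenyl for another, a 2.3-fold higher number from compound 2 to compound 3 (0.36 log units; beyond the scatter), which was modest, and the hydrogen-to-trifluoromethyl step, an at least 1.1-fold lower number from compound 1 to compound 3 (0.05 log units; that floor lies within the scatter), which stayed within scatter. For the measured compounds named here, with no measured precedent for the entering group, the expectation in this assay is a step no larger than the scatter, in either direction. Compound 4 is therefore estimated at 40000 nM, with a range from 15000 nM to 100000 nM. That estimate amounts to a 1.1-fold lower number from compound 3 to compound 4 (0.04 log units; within the scatter), meaning no change beyond scatter is expected.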

Compound 4, half-maximal inhibitory concentration: > 50000 nM
Compound 4: a limit, no number (the forecaster's own chance of this, stated with the estimate: 40%); middle value at least 1.2-fold (0.09 log units) from the limit.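

In this assay compound 4 gives > 50000 nM, which is a limit of the assay and not a number. The first ring with hetero atoms on this carbonyl carbon, pyrimidin-4-yl, does not hold the reading of the 2-fluorophenyl amide, with an at least 2.5-fold higher number from compound 2 to compound 4 (0.41 log units; beyond the scatter), whereas an at least 1.1-fold higher number from compound 3 to compound 4 (0.05 log units; that floor lies within the scatter) is only a floor and does not separate it from the 4-(trifluoromethyl)phenyl amide. The step between the two compounds at the limit, the phenyl and pyrimidin-4-yl amides, cannot be read, and the upper end of the series is now bounded by the assay and not by a measured number: the limit of > 50000 nM in this assay, at which 2 of the 4 values shown sit.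

The pyrimidin-4-yl change swaps the whole 2-fluorophenyl group in one step, so the shares of the lost fluoro and the entering ring nitrogens in that step stay unresolved, and a plain pyridine ring on the same carbonyl carbon would separate them. From the compounds shown here alone, whether this position tolerates anything other than an aromatic ring also stays open, for instance a carbonyl carbon bearing an amine or a phenyl ring bearing a carboxylic acid.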